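Removing the Ester Acyl Group of Compound 1 Altogether

This account rests on a few compounds, and the source may have more. Where it says the series, first, only, none or still open, it means among the compounds named here.

Compound 1 `Cc1ccc(C(=O)OC2(C(=O)Nc3ccc([N+](=O)[O-])cc3)CCCCC2)cc1` is the point of departure. In an ADME assay on WI-38 cells (Homo sapiens) for inhibition, read by MTT assay, with a stated time of 72 h (on this read-out lower numbers stand for stronger inhibition and higher numbers for weaker inhibition), compound 1 gives 32 nM, the lowest of the three numbers measured. Compound 2 `O=C(OC1(C(=O)Nc2ccc([N+](=O)[O-])cc2)CCCCC1)C(O)c1ccccc1` gives 84.4 nM in this assay, and compound 3 `O=C(CCC(=O)OC1(C(=O)Nc2ccc([N+](=O)[O-])cc2)CCCCC1)OC1(C(=O)Nc2ccc([N+](=O)[O-])cc2)CCCCC1` gives 203 nM. Within the data shown here, the only single-point step among them, a 2.6-fold higher number from compound 1 to compound 2 (0.42 log units; beyond the scatter), shows that changing the group attached to the ester carbonyl already moves the number beyond the scatter. Compound 4 `O=C(Nc1ccc([N+](=O)[O-])cc1)C1(O)CCCCC1` goes further: hydrogen in place of (4-methylphenyl)carbonyl on an oxygen on a saturated carbon, leaving that oxygen bearing only hydrogen. Among the measured compounds shown here, no measured pair shows exactly this change. What the data do show is that compound 2, with a different acyl group, and compound 3, with a larger ester arrangement, both give higher numbers than compound 1. Compound 4 is therefore expected to give a higher number again, probably by more than the step seen for the acyl exchange alone, though the size is uncertain. Compound 4 is estimated at 250 nM in this assay, within 50 nM to 1500 nM. The step this implies, a 7.8-fold higher number from compound 1 to compound 4 (0.89 log units; beyond the scatter), is an expectation only.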

Compound 4, half-maximal inhibitory concentration: 1220 nM
Compound 4: the middle estimate sits 4.9-fold (0.69 log units) below what was measured; the range from low to high includes it.
By their numbers in this assay, from the lowest: compound 1; then compound 2; then compound 3; then compound 4.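

Replacing the (4-methylphenyl)carbonyl on the oxygen with hydrogen gives a 38-fold higher number from compound 1 to compound 4 (1.58 log units; beyond the scatter) in this assay, so losing the acyl group altogether counts for far more at this position than exchanging it, which gave a 2.6-fold higher number from compound 1 to compound 2 (0.42 log units; beyond the scatter) for the same read-out. Compounds 1 and 2 had shown only that the number responds to the identity of the acyl group, whereas compound 4 shows what happens when that oxygen bears only hydrogen. Nothing available explains the size of this step.

The compounds shown leave open whether the aromatic ring or the carbonyl of the departing group accounts for the step. Going by these compounds, an acetyl group or a simple methyl ether on this oxygen could separate the two, and how either would fall relative to compound 1 remains unknown.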